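Methoxy to methyl on the aryl ring: cytotoxicity notes

A few compounds are considered here, and "the series" means these few. Any claim that something is new, unique, unknown or untested is made for them only; others in the source may bear on it.

Compound 1 `COc1ccc(-c2nnc(COc3ccc(C#N)cc3OC)o2)cc1` and compound 2 `COc1cc(C#N)ccc1OCc1nnc(-c2ccc(C)cc2)o1` share one core and differ by methyl in place of methoxy on an aromatic carbon. In an ADME assay on MCF-10A cells (Homo sapiens) for cytotoxicity, read by MTT assay, with a stated time of 48 h (on this read-out lower numbers stand for stronger inhibition and higher numbers for weaker inhibition), compound 1 gives > 100000 nM, a limit of the assay. In this assay compound 2 gives > 100000 nM, also a limit. The step that the two limits leave unreadable from compound 1 to compound 2 is therefore without a readable size; the measured values sit at the limit of > 100000 nM in this assay, at which 3 of the 3 values shown sit. Compound 3 `COc1ccc(-c2nnc(COc3ccc(-c4nnco4)cc3)o2)cc1` has a different core; the difference between the two cores is not broken down here. In this assay compound 3 gives > 100000 nM, again a limit. Compound 4 `Cc1ccc(-c2nnc(COc3ccc(-c4nnco4)cc3)o2)cc1` is not yet measured and differs from compound 3 by methyl in place of methoxy on an aromatic carbon, the same change as between compound 1 and compound 2. A step of a number no higher from compound 3 to compound 4 (the limit leaves the size open) is expected. This rests on compound 1 and compound 2 both sitting at the limit of > 100000 nM in this assay, at which 3 of the 3 values shown sit. Compound 4 is expected near 100000 nM, between 50000 nM and 200000 nM, most likely reported as a limit.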

Compound 4, half-maximal inhibitory concentration: > 100000 nM
Compound 4: only a limit was reported (the forecaster's own chance of this, stated with the estimate: 85%); the middle value lies on the limit itself.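

The step from compound 3 to compound 4 cannot be read in this assay, since both values are limits: the limit of > 100000 nM in this assay, at which 4 of the 4 values shown sit.

The compounds shown leave open whether methyl in place of methoxy changes cytotoxicity at all, and how large any such change would be.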